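The source may report more compounds than this note shows. Statements on the series, on what has been measured and on what is new or still open speak of the compounds shown alone.

Compound 1: `COc1cc(N)c(Cl)cc1C(=O)NC1CCN2C[C@H](c3ccccc3)CC2C1` gives > 3 mg/kg
Compound 2: `COc1cc(N)c(Cl)cc1C(=O)NC1CCN2CC(c3ccc(F)cc3)CC2C1` gives 0.015 mg/kg

In a functional assay on the whole organism for antagonist activity, with Mus musculus as the target (a higher number here means that more compound is needed for the effect, a lower number that less compound is needed), compound 2 gives 0.015 mg/kg, the only actual number among these two results. Compound 1 instead sits at the limit of this assay, > 3 mg/kg (the limit of > 3 mg/kg in this assay, at which 1 of the 2 values shown sits), which is not a number. Compound 3 `COc1cc(N)c(Cl)cc1C(=O)NC1CCN2CC(c3ccccc3F)CC2C1` differs from compound 2 in one place: 2-fluorophenyl in place of 4-fluorophenyl on a saturated ring carbon. Within the data shown here, no measured pair shows this kind of change, so its size cannot be read from the data. For compound 3 a moderate loss in this assay is expected, a step of a 6.7-fold higher number from compound 2 to compound 3 (0.82 log units; beyond the scatter). The estimate for compound 3 is 0.1 mg/kg, with a range from 0.01 mg/kg to 1 mg/kg.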

Compound 3, dose for half-maximal effect: 0.03 mg/kg
Compound 3: the middle estimate sits 3.3-fold (0.52 log units) above what was measured, and the stated range covers the measured number.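

In this assay, 2-fluorophenyl in place of 4-fluorophenyl on this saturated ring carbon gives a 2.0-fold higher number from compound 2 to compound 3 (0.30 log units; within the scatter). The two placements of the fluorine therefore cannot be told apart in this whole-animal test, and compounds 2 and 3 together show that this swap on the phenyl ring is tolerated. Nothing measured here offers a reason for this result.

Still open, from the compounds shown here alone, is whether this tolerance extends to other groups on the phenyl ring, such as a methoxy or a trifluoromethyl group. A pyridine ring in place of the phenyl ring is equally untested by the compounds shown.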